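The source may hold more compounds than are shown below. What is called first, only, known or untested is meant among the compounds shown, and "the series" means these compounds.

In an ADME assay (liver) for metabolic stability, with Liver microsome (Homo sapiens) as the target, using microsomes (on this read-out lower numbers stand for slow clearance and higher numbers for fast clearance), compound 1 (`c1ccc(CNc2nnc(-c3ccc4cnccc4c3)o2)cc1`) gives 120 mL.min-1.g-1 while compound 2 (`c1ccc(CNc2nnc(-c3nc4ccncc4s3)o2)cc1`) gives 23 mL.min-1.g-1 and compound 3 (`Fc1ccccc1CNc1nnc(-c2c[nH]c3ncccc23)o1`) gives 32 mL.min-1.g-1 on the same scale. Compound 3 thus stands within the scatter of compound 2 and at a clearly lower number than compound 1. Compound 4 (`Fc1ccc(CNc2nnc(-c3c[nH]c4ncccc34)o2)cc1`) is still unmeasured and has 4-fluorophenyl in place of 2-fluorophenyl on a saturated chain carbon bound to a nitrogen on an aromatic ring. Going by the values given here, no measured pair shows such a change, so in this assay no step beyond the scatter is expected in either direction. The expected change is small (a 1.1-fold higher number from compound 3 to compound 4 (0.04 log units; within the scatter)). Compound 4 is estimated at 35 mL.min-1.g-1 with an expected range from 15 mL.min-1.g-1 to 80 mL.min-1.g-1 in this read-out.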

Compound 4, intrinsic clearance in microsomes: 47 mL.min-1.g-1
Beside the measured number, compound 4's estimate is 1.3-fold (0.13 log units) below it; the measured number falls inside the stated range.
By their numbers in this assay, from the lowest: compounds 2, 3 and 4 (each within the scatter of the next, the first and the last beyond it); then compound 1.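

In this assay putting 4-fluorophenyl in place of 2-fluorophenyl on a saturated chain carbon bound to a nitrogen on an aromatic ring gives a 1.5-fold higher number from compound 3 to compound 4 (0.17 log units; within the scatter) and so stays within the scatter. This first single-place comparison does not tell the two fluorophenyl groups apart at this place. No supporting finding accounts for the result or ties it to a property of either group. The compounds shown leave open whether 3-fluorophenyl would fall with these two. They also leave open whether a methoxyphenyl or pyridyl group at this place would move the number beyond the scatter.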